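The source may hold more compounds than are shown below. What is called first, only, known or untested is meant among the compounds shown, and "the series" means these compounds.

The measured compounds are:

Compound 1, `CNC(=O)c1cc(-c2ccc(NS(=O)(=O)c3cccc(Cl)c3Cl)cc2)nc2[nH]ncc12`: 4 nM
Compound 2, `NCCNC(=O)c1cc(-c2ccc(NS(=O)(=O)c3cccc(Cl)c3Cl)cc2)nc2[nH]ncc12`: its value is a limit of the assay, < 1 nM
Compound 3, `Cc1n[nH]c2nc(-c3ccc(NS(=O)(=O)c4cc(Cl)ccc4F)cc3)nc(OCC3(CN)COC3)c12`: 1 nM

In an assay for inhibition of serine/threonine-protein kinase Sgk1 (Homo sapiens), with stated times of 30 min and 60 min, in the presence of a further agent that is not named here (on this read-out lower numbers stand for stronger inhibition and higher numbers for weaker inhibition), compound 3 gives the lowest of the two plain numbers shown. Its nearest neighbour is compound 1, whose number is higher by a margin beyond the usual scatter. Compound 2 stands at the limit of the assay, so no number can be set against it; the limit of < 1 nM in this assay, at which 1 of the 3 values shown sits, records this.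

Compound 4, `Cc1n[nH]c2nc(-c3ccc(NS(=O)(=O)c4cc(Cl)ccc4F)cc3)nc(OC3CC(C)(C)NC(C)(C)C3)c12`, differs from compound 3 by 2,2,6,6-tetramethylpiperidin-4-yl in place of (3-(aminomethyl)oxetan-3-yl)methyl on an oxygen on an aromatic ring. For the measured compounds named here, only one measured step is available, an at least 4.0-fold lower number from compound 1 to compound 2 (0.60 log units; beyond the scatter), and it concerns a different place on the shared core: an added aminomethyl on a chain carbon bound to an amide-type nitrogen, not the group on the aromatic oxygen. It therefore bears only loosely on the present change. Both compound 3 and compound 4 carry a nitrogen-bearing group on that oxygen, and the measured step offers no direct guide to swapping one for the other. The expected step is a 1.5-fold higher number from compound 3 to compound 4 (0.18 log units; within the scatter), that is, no shift beyond the scatter. The estimate for compound 4 in this assay is 1.5 nM, with a range from 0.5 nM to 5 nM.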

Compound 4, half-maximal inhibitory concentration: 3 nM
For compound 4 the middle estimate is 2.0-fold (0.30 log units) below the measured one; low and high end bracket the measured number.
By their numbers in this assay, from the lowest: compound 3; then compounds 4 and 1 (each within the scatter of the next).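

In this assay, for the compounds shown here, the step at the oxygen on an aromatic ring gives the first reading at this place: a 3.0-fold higher number from compound 3 to compound 4 (0.48 log units; beyond the scatter). The change of group therefore registers in this assay, though only modestly: with (3-(aminomethyl)oxetan-3-yl)methyl replaced by the larger 2,2,6,6-tetramethylpiperidin-4-yl, which has a six-membered rather than a four-membered ring, compound 4 still gives 3 nM. The information available offers no explanation for the size or direction of this step.

Both groups at this place contain a nitrogen and a non-aromatic ring, so the compounds shown leave open how a group without nitrogen, such as a plain methyl or a hydroxyethyl chain, would read on the same oxygen. They also do not separate the contributions of ring size, the oxetane oxygen and the methyl groups on the piperidine, which an unsubstituted piperidin-4-yl or an azetidin-3-yl group on that oxygen would help to tell apart.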